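A Methyl Added Where Nothing Yet Inhibits

A few compounds are considered here, and "the series" means these few. Any claim that something is new, unique, unknown or untested is made for them only; others in the source may bear on it.

Compound 1 `O=c1cc(CSc2nc3ccccc3s2)oc2ccccc12` was tested in a functional assay on MCF7 cells (Homo sapiens) for cytotoxicity, read by MTT assay, with a stated time of 72 h; on this read-out higher numbers stand for weaker inhibition and lower numbers for stronger inhibition. In this assay compound 1 reaches only the limit of the assay, > 25000 nM, and not a number. Compound 3 `Cc1ccc2oc(CSc3nc4ccccc4s3)cc(=O)c2c1` carries one change from compound 1, (methyl in place of hydrogen on an aromatic carbon). In this assay compound 3 likewise gives only a limit, > 25000 nM. The step that the two limits leave unreadable from compound 1 to compound 3 therefore cannot be sized, since both ends are limits. Compound 2 `Cc1nnc(SCc2cc(=O)c3ccccc3o2)s1` shares the part of the molecule that bears the carbonyl with compound 1 but differs in the other ring system; the difference between the two cores is not broken down here. In this assay compound 2 again gives only a limit, > 25000 nM. Going by the values given here, what the three share is the limit of > 25000 nM in this assay, at which 3 of the 3 values shown sit, so nothing measured so far separates any of them.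

Compound 4 `Cc1ccc2oc(CSc3nnc(C)s3)cc(=O)c2c1` has not been tested. It stands to compound 2 as compound 3 stands to compound 1: methyl in place of hydrogen on an aromatic carbon, the same change at the same place. Because compound 1 and compound 3 leave a step that the two limits leave unreadable from compound 1 to compound 3 unreadable, there is no measured size to carry over. The expectation is that compound 4 will also sit at the limit, so the step that the limit leaves unreadable from compound 2 to compound 4 is estimated to be nothing that the assay can show. Compound 4 is thus expected to give about 40000 nM in this assay, most likely reported only as a limit, with a range from 15000 nM to 150000 nM.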

Compound 4, half-maximal inhibitory concentration: > 25000 nM
Compound 4 was reported as a limit (the forecaster's own chance of this, stated with the estimate: 85%); the middle value does not contradict the limit.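

Compound 2 and compound 4 both stand in this assay as limits and not as numbers, so no step can be read between them for methyl in place of hydrogen on an aromatic carbon. The compounds shown leave open whether that methyl or the difference between the two cores changes inhibition at all, since nothing separates them: the limit of > 25000 nM in this assay, at which 4 of the 4 values shown sit.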